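The source may hold more compounds than are shown below. What is called first, only, known or untested is meant among the compounds shown, and "the series" means these compounds.

Among the compounds with values here, compound 1 `CCCCCSc1nc(N)c2nc(O)n(Cc3ccccc3)c2n1` is the only compound here with a measured number: in a functional assay (spleen, spleen) for activation, with Mus musculus as the target (on this read-out lower numbers stand for an effect already at smaller amounts and higher numbers for an effect only at larger amounts of compound), compound 1 gives 10 uM. Compound 2 `COc1nc2c(N)ncnc2n1Cc1ccccc1` reaches only a limit of the assay, > 10 uM. Compound 3 `NNc1nc2c(N)ncnc2n1Cc1ccccc1` likewise reaches only a limit, > 10 uM. The step that the two limits leave unreadable from compound 2 to compound 3 therefore cannot be read, and this leaves the limit of > 10 uM in this assay, at which 2 of the 3 values shown sit, as the main evidence. Compound 4 `CCCOc1nc(N)c2nc(O)n(Cc3ccccc3)c2n1` differs from compound 1 by propoxy in place of pentylsulfanyl on an aromatic carbon. Within the data shown here, no measured step touches this change, so no size or direction can be drawn from the others. Compound 4 is estimated at 20 uM, with a range from 5 uM to 80 uM. This estimate means a step of a 2.0-fold higher number from compound 1 to compound 4 (0.30 log units; within the scatter) that is expected, with a real chance that compound 4 also ends at a limit.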

Compound 4, minimum effective concentration: 0.01 uM
For compound 4 the middle estimate is 2000-fold (3.30 log units) above the measured one; the measured number lies below the stated range.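

In this assay the swap of pentylsulfanyl for propoxy, on the aromatic carbon between two ring nitrogen atoms, gives a 1000-fold lower number from compound 1 to compound 4 (3.00 log units; beyond the scatter) and shows that this position is far from indifferent to what it carries. Within the data shown here, the earlier compounds could not show this, since the only step among them cannot be read. Nothing shown explains why this single change has so large an effect.

As far as these compounds go, the sulfur and the chain length change together here, so it stays open which of them matters. A propylsulfanyl or a pentyloxy group would separate the two.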